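Chain substituent swaps on the shared core: clearance notes

The source may report more compounds than this note shows. Statements on the series, on what has been measured and on what is new or still open speak of the compounds shown alone.

Compound 3 `OC1(COc2ccc([C@H]3CC[C@]4(CC3)OOC3(O4)C4CC5CC(C4)CC3C5)cc2)CCNCC1` gives 16 mL.min-1.g-1 in an ADME assay on microsomes from liver (Homo sapiens) for metabolic stability, read by LC-MS, tested at 1 uM; a higher number here means faster removal of the compound, a lower number slower removal. Compound 1 `NCCOc1ccc([C@H]2CC[C@]3(CC2)OOC2(O3)C3CC4CC(C3)CC2C4)cc1` sits at the assay limit, giving < 7 mL.min-1.g-1 in this assay. Compound 2 `c1cc([C@H]2CC[C@]3(CC2)OOC2(O3)C3CC4CC(C3)CC2C4)ccc1OCCC1CCNCC1` also sits at the assay limit, giving < 7 mL.min-1.g-1 in this assay. Going by the values given here, compound 3 thus holds the only number among the three (the limit of < 7 mL.min-1.g-1 in this assay, at which 2 of the 3 values shown sit). Compound 4 `CS(=O)(=O)N1CCN(CCCOc2ccc([C@H]3CC[C@]4(CC3)OOC3(O4)C4CC5CC(C4)CC3C5)cc2)CC1` is not yet measured and differs from compound 3 by 2-(4-(methylsulfonyl)piperazin-1-yl)ethyl in place of 4-hydroxypiperidin-4-yl on a saturated chain carbon bound to an oxygen on an aromatic ring. The steps bearing on this position are an at least 2.2-fold higher number from compound 1 to compound 3 (0.35 log units; beyond the scatter) and an at least 2.2-fold higher number from compound 2 to compound 3 (0.35 log units; beyond the scatter), both arriving at 4-hydroxypiperidin-4-yl. Among the compounds with values here, compound 4 moves away from that group again, so a step back downward is expected, a 1.8-fold lower number from compound 3 to compound 4 (0.25 log units; within the scatter), though no measured step covers 2-(4-(methylsulfonyl)piperazin-1-yl)ethyl itself. Compound 4 is therefore estimated at 9 mL.min-1.g-1, within 5 mL.min-1.g-1 to 20 mL.min-1.g-1, with a real chance of only a limit.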

Compound 4, intrinsic clearance in microsomes: 68 mL.min-1.g-1
The estimate for compound 4 lay 7.6-fold (0.88 log units) below the measured number, and the stated range ends below it.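

In this assay, this position on the shared core can carry far faster removal than 4-hydroxypiperidin-4-yl gave: 2-(4-(methylsulfonyl)piperazin-1-yl)ethyl brings a 4.3-fold higher number from compound 3 to compound 4 (0.63 log units; beyond the scatter). Measured against the two compounds held at a limit, the rise reads as an at least 9.7-fold higher number from compound 2 to compound 4 (0.98 log units; beyond the scatter) and as an at least 9.7-fold higher number from compound 1 to compound 4 (0.98 log units; beyond the scatter). Going by these compounds alone, the change therefore continues the upward direction of the earlier steps rather than reversing it.

As far as these compounds go, whether the rise follows the methylsulfonyl group or the piperazine stays open; an acetyl group on that piperazine, or a morpholine in its place, would separate the two. The low end of the series also gives no sizes: the limit of < 7 mL.min-1.g-1 in this assay, at which 2 of the 4 values shown sit.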